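Indane for Phenyl at the Oxalamide Nitrogen: Compound 4 Estimated

A few compounds are considered here, and "the series" means these few. Any claim that something is new, unique, unknown or untested is made for them only; others in the source may bear on it.

Compound 1 `C[C@H](NC(=O)C(=O)Nc1ccccc1)C(=O)N[C@@H](CC(=O)O)C(=O)COc1c(F)c(F)cc(F)c1F`: 140 nM
Compound 2 `C[C@H](NC(=O)C(=O)Nc1ccccc1-c1ccccc1)C(=O)N[C@@H](CC(=O)O)C(=O)COC(=O)c1c(F)c(F)cc(F)c1F`: 500 nM
Compound 3 `C[C@H](NC(=O)C(=O)Nc1ccccc1Oc1ccccc1)C(=O)N[C@@H](CC(=O)O)C(=O)COc1c(F)c(F)cc(F)c1F`: 800 nM

In a functional assay on THP-1 cells (Homo sapiens) for inhibition (on this read-out higher numbers stand for weaker inhibition and lower numbers for stronger inhibition), compound 1 stands lowest of the three measured compounds. In this assay a higher number than that of compound 1 is given by compound 2, which differs from compound 1 in two places: compound 2 gives 500 nM. Compound 3 differs from compound 1 in a single place, and a 5.7-fold higher number from compound 1 to compound 3 (0.76 log units; beyond the scatter) describes that step: a phenoxy in place of hydrogen on an aromatic carbon gives a modestly higher number.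

Compound 4 `C[C@H](NC(=O)C(=O)Nc1ccc2c(c1)CCC2)C(=O)N[C@@H](CC(=O)O)C(=O)COc1c(F)c(F)cc(F)c1F` is not yet measured. It differs from compound 1 as follows: 2,3-dihydro-1H-inden-5-yl in place of phenyl on an amide-type nitrogen. The ring that enters carries one five-membered non-aromatic ring of carbon only alongside the aromatic ring, so, like the step to compound 3, it adds carbon atoms to the phenyl of compound 1. Among the compounds with values here, the only measured step that bears on this, from compound 1 to compound 3, went towards a higher number and was beyond the scatter, though the group added here is smaller than a phenoxy and of a different kind.

Compound 4 is therefore expected to give a somewhat higher number than compound 1, a step of a 2.1-fold higher number from compound 1 to compound 4 (0.33 log units; beyond the scatter) in this assay. The estimate for compound 4 is 300 nM, with a range from 120 nM to 800 nM.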

Compound 4, half-maximal inhibitory concentration: 120 nM
For compound 4 the middle estimate is 2.5-fold (0.40 log units) above the measured one; low and high end bracket the measured number.
By their numbers in this assay, from the lowest: compounds 4 and 1 (each within the scatter of the next); then compounds 2 and 3 (each within the scatter of the next).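

In this assay, the replacement of phenyl by 2,3-dihydro-1H-inden-5-yl on an amide-type nitrogen gives a 1.2-fold lower number from compound 1 to compound 4 (0.07 log units; within the scatter), so this change of the group on that nitrogen brings more carbon atoms without moving the number beyond the scatter. Within the data shown here, until now the only single change to the phenyl of compound 1 was the phenoxy, with a 5.7-fold higher number from compound 1 to compound 3 (0.76 log units; beyond the scatter), so the new step shows that added carbon on this aromatic group does not in itself go with a higher number; compound 3 remains the one case here that does. Nothing measured here accounts for the difference between these two steps.

What the compounds shown leave open is whether this tolerance extends to groups of another kind, such as an amine, a carboxylic acid or a longer chain in place of the 2,3-dihydro-1H-inden-5-yl on the amide-type nitrogen. From the compounds shown here alone, compound 2 differs from compound 1 in two places, so the share of each of its changes in its number also stays open.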